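The source may hold more compounds than are shown below. What is called first, only, known or untested is meant among the compounds shown, and "the series" means these compounds.

Measured so far:
- compound 1, `C/C=C/C(=O)N(Cc1cccc(O)c1)c1cc(OC)c(OC)c(OC)c1`: 14700 nM
- compound 2, `CCC(=O)N(Cc1ccc(OC)c(O)c1)c1cc(OC)c(OC)c(OC)c1`: 98 nM

Both numbers come from a functional assay on KYSE-450 cells (Homo sapiens) for inhibition, read by MTT assay, with a stated time of 48 h; on this read-out lower numbers stand for stronger inhibition and higher numbers for weaker inhibition. For the measured compounds named here, compound 2 stands at the lowest of the two values, and compound 1 sits at a considerably higher number, a gap well beyond the usual scatter of the read-out; no single-point step between the two is defined, so only the two values themselves are compared here.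

The next compound, compound 3, `COc1ccc(CN(C(=O)CCl)c2cc(OC)c(OC)c(OC)c2)cc1O`, is so far unmeasured. Against compound 2 the change is chloro in place of methyl on a saturated chain carbon bound to a carbonyl carbon, which is to say propanoyl becomes (chloromethyl)carbonyl on the same core. Going by the values given here, no measured pair in the set shows this change, so there is no direct precedent for its size or direction in this assay.

Given that compound 2 gives 98 nM in this assay and the change exchanges one heavy atom for another without altering donors, acceptors or charge, the step from compound 2 to compound 3 is expected to be small, a 1.5-fold higher number from compound 2 to compound 3 (0.18 log units; within the scatter), and may well lie within the scatter. Compound 3 is accordingly estimated at 150 nM, with a range from 40 nM to 600 nM.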

Compound 3, half-maximal inhibitory concentration: 210 nM
Compound 3: the middle estimate sits 1.4-fold (0.15 log units) below what was measured; measured number inside the range.
By their numbers in this assay, from the lowest: compound 2; then compound 3; then compound 1.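

In this assay, for the compounds shown here, chloro in place of methyl on a saturated chain carbon bound to a carbonyl carbon gives a 2.1-fold higher number from compound 2 to compound 3 (0.33 log units; beyond the scatter), the first step that can be read at a single place. The step is modest and only just beyond the scatter, so this position responds to the exchange, yet compound 3 at 210 nM stays close to compound 2, and the change on the shared core costs little in this read-out. Nothing at hand accounts for the direction or the size of this step.

Compound 1 differs from both compounds in more than one place, so its value says nothing about this position. Still open, as far as these compounds go, is how an amine, a methoxy or a bromo on this same carbon would compare with methyl and chloro, and whether a longer chain such as butanoyl would hold the number near that of compound 2.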